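A ring on the side chain of compound 2

The source may report more compounds than this note shows. Statements on the series, on what has been measured and on what is new or still open speak of the compounds shown alone.

In a functional assay on K562 cells (Homo sapiens) for cytotoxicity, read by fluorescence, with a stated time of 72 h (on this read-out higher numbers stand for weaker inhibition and lower numbers for stronger inhibition), compound 1 `CC(C)c1n[nH]c2c(NCc3ccc(-c4ccccn4)cc3)nc(NCCO)nc12` gives 38 nM, and compound 2 `CC(C)c1n[nH]c2c(NCc3ccc(-c4ccccn4)cc3)nc(NCCN)nc12` gives 63 nM. Among the compounds with values here, these two values lie within the usual scatter of each other, so compound 2 stands level with compound 1, the only other compound measured so far.

Compound 3 `CC(C)c1n[nH]c2c(NCc3ccc(-c4ccccn4)cc3)nc(N[C@@H]3CCCC[C@H]3N)nc12` keeps the shared core of both but carries 2-aminocyclohexyl in place of 2-aminoethyl on a nitrogen on an aromatic ring. Within the data shown here, only one measured step bears on this change, and only indirectly. In a 1.7-fold higher number from compound 1 to compound 2 (0.22 log units; within the scatter), amino replaces hydroxy on the same side chain, and the number stays within the scatter. That step swaps one group on an open chain and tests no ring, so the data say little about a change of this kind.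

Among the measured compounds shown here, with that small step as the only guide, no shift beyond the scatter is expected in this assay. The expected change is a 1.6-fold lower number from compound 2 to compound 3 (0.20 log units; within the scatter). For compound 3 the estimate is 40 nM, with an expected range from 10 nM to 150 nM.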

Compound 3, half-maximal inhibitory concentration: 175 nM
Compound 3: middle estimate off by 4.4-fold (0.64 log units), on the low side; the measured number lies above the stated range.
By their numbers in this assay, from the lowest: compounds 1 and 2 (each within the scatter of the next); then compound 3.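

In this assay, within the data shown here, the swap of 2-aminoethyl for 2-aminocyclohexyl gives a 2.8-fold higher number from compound 2 to compound 3 (0.44 log units; beyond the scatter) and is the first step at this position to go beyond the scatter, whereas the earlier exchange of hydroxy for amino on the open chain stayed within it. The step from the other open chain, with 2-aminocyclohexyl in place of 2-hydroxyethyl, agrees and gives a 4.6-fold higher number from compound 1 to compound 3 (0.66 log units; beyond the scatter), so the group on this nitrogen on an aromatic ring can change the number, modestly here, and compound 3 is the weakest of the three. Nothing measured in these data accounts for the shift.

The new group differs from the old one in several ways at once, with more carbon, a six-membered ring and two defined stereocentres, and these three compounds cannot show which of those differences matters. An open chain of similar size such as 6-aminohexyl, a smaller ring such as 2-aminocyclopentyl, the other stereoisomers of 2-aminocyclohexyl and a ring that carries hydroxy, such as 2-hydroxycyclohexyl, would each help to pull those differences apart.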